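Amine side chains in the series: compound 3 to compound 4

The compounds below may be only part of what the source reports. "The series", "measured", "known", "first", "only" and "open" are said of these compounds alone.

- compound 1 `CCCOc1c(-c2cc(OC)c(OC)c(OC)c2)oc2ccccc2c1=O`: 2800 nM
- compound 2 `CCN(CC)CCCOc1c(-c2cc(OC)c(OC)c(OC)c2)oc2ccccc2c1=O`: > 50000 nM, a limit of the assay
- compound 3 `CCCN(CCC)CCCCOc1c(-c2cc(OC)c(OC)c(OC)c2)oc2ccccc2c1=O`: 35800 nM

In a functional assay on DU-145 cells (Homo sapiens) for antiproliferative activity, read by WST assay, with a stated time of 3 days (on this read-out lower numbers stand for stronger inhibition and higher numbers for weaker inhibition), compound 3 gives 35800 nM, the higher of the two exact numbers. The next structure, compound 4 `CCCCN(CCCC)CCCCOc1c(-c2cc(OC)c(OC)c(OC)c2)oc2ccccc2c1=O`, differs by dibutylamino in place of dipropylamino on a saturated chain carbon, four bonds along the chain from an oxygen on an aromatic ring: dibutylamino in place of dipropylamino. Two large steps show the cost of adding the amine chains: an at least 17-fold higher number from compound 1 to compound 2 (1.25 log units; beyond the scatter) and a 13-fold higher number from compound 1 to compound 3 (1.11 log units; beyond the scatter). The closest comparison among the amines is an at least 1.3-fold lower number from compound 2 to compound 3 (0.14 log units; that floor lies within the scatter), and it shows no change beyond the scatter. A similarly small effect is therefore expected here, with no step beyond the scatter: a 1.3-fold lower number from compound 3 to compound 4 (0.11 log units; within the scatter). For compound 4 the estimated value is 28000 nM, with an expected range of 9000 nM to 50000 nM.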

Compound 4, half-maximal inhibitory concentration: 15300 nM
Beside the measured number, compound 4's estimate is 1.8-fold (0.26 log units) above it; measured number inside the range.
By their numbers in this assay, from the lowest: compound 1; then compound 4; then compound 3. At a limit, above all of these: compound 2.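

Dibutylamino in place of dipropylamino gives the first step among the amines that lies beyond the scatter in this assay: a 2.3-fold lower number from compound 3 to compound 4 (0.37 log units; beyond the scatter). The side chain without an amine still gives the lower number, with a 5.5-fold higher number from compound 1 to compound 4 (0.74 log units; beyond the scatter). The remaining step starts from a limit of the assay and reads an at least 3.2-fold lower number from compound 2 to compound 4 (0.51 log units; beyond the scatter): the limit of > 50000 nM in this assay, at which 1 of the 4 values shown sits.

Open, going by these compounds, is how dipentylamino, or a ring amine such as piperidine or morpholine, would read at this place. The compounds shown also do not tell why dibutylamino gives the lower number.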